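The source may report more compounds than this note shows. Statements on the series, on what has been measured and on what is new or still open speak of the compounds shown alone.

Going by the values given here, in an assay on isolated protein for inhibition of Gonadotropin-releasing hormone receptor (Homo sapiens) (on this read-out lower numbers stand for stronger inhibition and higher numbers for weaker inhibition), compound 3 `COc1ccc([N+](=O)[O-])cc1CSc1nc2cc(NC(=O)OC(C)(C)C)ccc2n1C(C)C` gives 880 nM, the highest of the three numbers measured so far. The nearest number belongs to compound 1 `COc1ccc(C#N)cc1CSc1nc2cc(NC(=O)C3CC3)ccc2n1C(C)C`, which gives 570 nM in this assay, a value within the usual scatter of that of compound 3. The furthest belongs to compound 2 `CCCn1c(SCc2cc([N+](=O)[O-])ccc2OC)nc2cc(NC(=O)NC(C)(C)C)ccc21`, which gives 18 nM in this assay; compound 2 differs from compound 3 in more than one place, so its two values show only that the gap between them lies well beyond the scatter.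

Compound 4 `COc1ccc([N+](=O)[O-])cc1CSc1nc2cc(NC(=O)C(C)(C)C)ccc2n1C(C)C` has not yet been measured. It differs from compound 3 in one place: tert-butyl in place of tert-butoxy on a carbonyl carbon. Among the compounds with values here, no pair of measured compounds isolates this particular change, so the effect has to be judged without a matched step. Compound 1 also carries a carbonyl on the amide-type nitrogen and gives a number within the scatter of compound 3, which gives no sign that the carbonyl substituent alone moves the read-out far. The step from compound 3 to compound 4 is therefore expected to be small, most likely within the scatter, with at most a modest move toward a lower number, as in a 1.5-fold lower number from compound 3 to compound 4 (0.17 log units; within the scatter). Compound 4 is estimated to give about 600 nM in this assay, with an expected range from 200 nM to 2000 nM.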

Compound 4, half-maximal inhibitory concentration: 180 nM
Compound 4: the middle estimate sits 3.3-fold (0.52 log units) above what was measured; the whole stated range lies above it.
By their numbers in this assay, from the lowest: compound 2; then compound 4; then compounds 1 and 3 (each within the scatter of the next).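

In this assay, going by these compounds alone, the step to tert-butyl from tert-butoxy on a carbonyl carbon is a 4.9-fold lower number from compound 3 to compound 4 (0.69 log units; beyond the scatter), the first matched comparison. It shows that the read-out at this position is sensitive to a small edit: the tert-butyl carbons remain, while the group goes from 5 heavy atoms to 4 and loses its single oxygen and its one hydrogen-bond acceptor. That single step cannot separate these differences from one another, and nothing measured here bears on why the number falls.

Compound 2 also carries a tert-butyl-bearing group on this carbonyl, as a tert-butylamino group, but it differs from compound 4 in more than one place, so the compounds shown do not tell how that nitrogen-linked version compares with the direct carbon link. On these data alone, it also remains open how a methyl, a longer chain such as n-butyl, or a group ending in an amine or a carboxylic acid would behave on this carbonyl carbon.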